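Compound 4: an expected stay near the limit

The source may report more compounds than this note shows. Statements on the series, on what has been measured and on what is new or still open speak of the compounds shown alone.

Compound 1 `CCc1cc2oc(=O)n(CCC(=O)O)c2cc1Cl`: < 10 nm/s (limit)
Compound 2 `CC(C)Cc1cc2oc(=O)n(CCC(=O)O)c2cc1Cl`: < 10 nm/s (limit)
Compound 3 `C[C@@H](Oc1cc2oc(=O)n(CCC(=O)O)c2cc1Cl)c1cccnn1`: < 3 nm/s (limit)

All three compounds measured in a physicochemical assay for permeability, using PAMPA (a lower number here means that the compound crosses the layer more slowly, a higher number that the compound crosses the layer faster), gave limits and no numbers. In this assay compound 3 stands at < 3 nm/s, which is a limit. Compound 4 `O=C(O)CCn1c(=O)oc2cc(OCc3ccccn3)c(Cl)cc21` differs from it as follows: a group of 7 heavy atoms (6 carbon, 1 nitrogen; one six-membered aromatic ring with 1 hetero atom) in place of a group of 8 heavy atoms (6 carbon, 2 nitrogen; one six-membered aromatic ring with 2 hetero atoms), on an oxygen on an aromatic ring. Going by the values given here, the one measured step is a step that the two limits leave unreadable from compound 1 to compound 2. It concerns a different change and offers no size to carry over. The expectation therefore rests on compound 3, with its limit of < 3 nm/s, and a result close to that limit is expected. The expected change is a number no lower from compound 3 to compound 4 (the limit leaves the size open), with no shift beyond the scatter. For compound 4 the estimate is 3 nm/s, with an expected range from 1 nm/s to 10 nm/s.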

Compound 4, apparent permeability: 11 nm/s
For compound 4 the middle estimate is 3.7-fold (0.56 log units) below the measured one; measured number above the stated range.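

In this assay, (pyridin-2-yl)methyl in place of the group of compound 3 on the oxygen on an aromatic ring gives an at least 3.6-fold higher number from compound 3 to compound 4 (0.56 log units; beyond the scatter), so a change at this place can lift the read-out clear of the limit of compound 3. The comparisons with the ethyl and isobutyl compounds give only floors, an at least 1.1-fold higher number from compound 1 to compound 4 (0.04 log units; that floor lies within the scatter) and an at least 1.1-fold higher number from compound 2 to compound 4 (0.04 log units; that floor lies within the scatter), and these do not separate compound 4 from either one. The earlier compounds offered no such step, as they stood at limits: the limit of < 10 nm/s in this assay, at which 2 of the 4 values shown sit.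

On these data alone, whether the step follows the ring's hetero atom count or the loss of the defined stereocentre stays open, as the change alters both. So does the effect of a longer chain on the oxygen, or of a methyl ester in place of the carboxylic acid.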